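The compounds below may be only part of what the source reports. "The series", "measured", "known", "first", "only" and "open" are said of these compounds alone.

In an ADME assay on CCRF-CEM cells (Homo sapiens) for cytotoxicity, with a stated time of 5 days (on this read-out lower numbers stand for higher toxicity in this test and higher numbers for lower toxicity in this test), compound 1 `Cc1nc(N)nc2c1ncn2[C@@H]1O[C@H](CO)[C@@H](O)[C@@]1(C)O` gives 13000 nM as a measured number. Compound 2 `C[C@@]1(O)[C@H](O)[C@@H](CO)O[C@H]1n1cnc2c(N)nc(NN)nc21` gives > 100000 nM as its result, and this is a limit of the assay, not a number. Within the data shown here, compound 3 `C[C@@]1(O)[C@H](O)[C@@H](CO)O[C@H]1n1cnc2c(N)nc(N=[N+]=[N-])nc21` differs from compound 2 at one place, with azido in place of aminoamino on an aromatic carbon as the only change. Among the measured compounds shown here, no measured step shows what this swap does, so only a small move toward higher toxicity in this assay is expected. The expected step is an at least 1.2-fold lower number from compound 2 to compound 3 (0.09 log units; that floor lies within the scatter) for this swap. For compound 3 the estimate is 80000 nM with an expected range of 25000 nM to 100000 nM in this test.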

Compound 3, half-maximal cytotoxic concentration: > 100000 nM
Compound 3 ended at the assay's limit (the forecaster's own chance of this, stated with the estimate: 55%); at least 1.2-fold (0.09 log units) between middle value and limit.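

Among these compounds, compound 2 and compound 3 both end at a limit rather than a number, so no step between them can be read: the limit of > 100000 nM in this assay, at which 2 of the 3 values shown sit. As far as these compounds go, whether azido in place of aminoamino changes the result in this assay stays open.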